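This account rests on a few compounds, and the source may have more. Where it says the series, first, only, none or still open, it means among the compounds named here.

Compound 2 `COc1ccccc1OC(C)(C)C1OCC(C/C=C\CCC(=O)O)C(c2cccnc2)O1` gives 51000 nM in an assay for inhibition of prostacyclin synthase (Homo sapiens), using microsomes (on this read-out lower numbers stand for stronger inhibition and higher numbers for weaker inhibition), the higher of the two numbers recorded so far; compound 1 `CSc1ccc(OC(C)(C)C2OCC(C/C=C\CCC(=O)O)C(c3cccnc3)O2)c([N+](=O)[O-])c1` gives 5000 nM in this assay. Compound 3 `COc1ccc(OC(C)(C)C2OCC(C/C=C\CCC(=O)O)C(c3cccnc3)O2)c([N+](=O)[O-])c1` carries 4-methoxy-2-nitrophenyl in place of 2-methoxyphenyl on an oxygen on a saturated carbon. Within the data shown here, the only measured step that bears on this change runs in the opposite direction: a 10-fold higher number from compound 1 to compound 2 (1.01 log units; beyond the scatter), where 2-methoxyphenyl replaced a larger nitro-bearing group. Restoring a nitro-bearing group in compound 3 is therefore expected to lower the number by a comparable amount, giving an 8.5-fold lower number from compound 2 to compound 3 (0.93 log units; beyond the scatter). Compound 3 is estimated at 6000 nM, with a likely range of 2000 nM to 20000 nM.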

Compound 3, half-maximal inhibitory concentration: 23000 nM
Estimate against measurement, compound 3: 3.8-fold (0.58 log units) below, and the stated range ends below it.
By their numbers in this assay, from the lowest: compound 1; then compound 3; then compound 2.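

Exchanging 2-methoxyphenyl for 4-methoxy-2-nitrophenyl on this oxygen gives only a 2.2-fold lower number from compound 2 to compound 3 (0.35 log units; beyond the scatter), so the nitro-bearing ring alone does not reproduce the whole gap seen earlier. The group on the aromatic carbon also matters: methoxy in place of methylsulfanyl gives a 4.6-fold higher number from compound 1 to compound 3 (0.66 log units; beyond the scatter), which places part of that gap with the sulfur-bearing group. No measurement given here explains either step. The compounds shown leave open how an amine or a chlorine on that aromatic carbon would compare with methylsulfanyl. They also leave open what the nitro group contributes without the other ring substituent.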